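This account rests on a few compounds, and the source may have more. Where it says the series, first, only, none or still open, it means among the compounds named here.

Measured compounds:
compound 1 `Cc1ccc(S(=O)(=O)Oc2ccc3c(CSc4nc5ccccc5c(=O)[nH]4)cc(=O)oc3c2)cc1` gives 117000 nM
compound 2 `Cc1ccc2nc(SCc3cc(=O)oc4cc(OS(=O)(=O)c5ccccc5)ccc34)[nH]c(=O)c2c1` gives 126000 nM

Both numbers come from an ADME assay on Vero cells (Chlorocebus sabaeus) for cytotoxicity, read by polymerase chain reaction, with a stated time of 18 h; on this read-out lower numbers stand for higher toxicity in this test and higher numbers for lower toxicity in this test. Compound 2 holds the highest of the two numbers, and its nearest neighbour is compound 1, whose number lies within the usual scatter of compound 2, so the two cannot be told apart on this read-out.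

Compound 3 `Cc1ccc(S(=O)(=O)Oc2ccc3c(CSc4nc5ccc(C)cc5c(=O)[nH]4)cc(=O)oc3c2)cc1` has not yet been measured in this assay. It differs from compound 2 by methyl in place of hydrogen on an aromatic carbon. No pair of measured compounds differing in a single place is available, so the effect of this change cannot be read from the shown numbers. Given that compound 1 and compound 2 sit so close together, the step expected from compound 2 to compound 3 is a 1.1-fold lower number from compound 2 to compound 3 (0.02 log units; within the scatter), none beyond the scatter. Compound 3 is therefore estimated at 120000 nM, with a range from 60000 nM to 240000 nM.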

Compound 3, half-maximal cytotoxic concentration: 114000 nM
For compound 3 the middle estimate is 1.1-fold (0.02 log units) above the measured one, and the stated range covers the measured number.
By their numbers in this assay, from the lowest: compounds 3, 1 and 2 (each within the scatter of the next).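

In this assay the first single-place comparisons become available: phenylsulfonyl to (4-methylphenyl)sulfonyl gives a 1.1-fold lower number from compound 2 to compound 3 (0.04 log units; within the scatter) and methyl in place of hydrogen on an aromatic carbon elsewhere in the molecule gives a 1.0-fold lower number from compound 1 to compound 3 (0.01 log units; within the scatter) on the same read-out. Both steps lie within the scatter, so methyl on this aromatic carbon, para to a large group, produces no change that this test can resolve, and compound 3, which carries both methyl groups, cannot be told apart from compound 1 or compound 2. No evidence is available that bears on this result.

The compounds shown leave open whether any other group at this position would give a step beyond the scatter. An amine, a carboxylic acid or a longer chain there is not among them.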